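Swapping a Methyl for a Fluoro on Compound 2

The compounds below may be only part of what the source reports. "The series", "measured", "known", "first", "only" and "open" are said of these compounds alone.

Within the data shown here, compound 2 `Cc1cccc(Cc2cnc(CCc3ccc(-c4ccccc4C(=O)O)cc3)[nH]2)c1` is the weaker of the two compounds measured so far: in an in vitro functional assay on cells for agonist activity at Bombesin receptor subtype-3 (Homo sapiens), read by luminescence and calcium flux (on this read-out higher numbers stand for an effect only at larger amounts of compound and lower numbers for an effect already at smaller amounts), compound 2 gives 4310 nM, whereas compound 1 `O=C(O)c1ccccc1-c1ccc(CCc2ncc(Cc3ccccc3Cl)[nH]2)cc1` gives 292 nM. Among the measured compounds shown here, the only step known, a 15-fold higher number from compound 1 to compound 2 (1.17 log units; beyond the scatter), came from exchanging one substituted phenyl for another. Compound 3 `O=C(O)c1ccccc1-c1ccc(CCc2ncc(Cc3cccc(F)c3)[nH]2)cc1` carries fluoro in place of methyl on an aromatic carbon. Since that earlier exchange a 15-fold higher number from compound 1 to compound 2 (1.17 log units; beyond the scatter) moved this assay by a large amount, a step beyond the scatter is expected here as well, toward smaller amounts of compound, estimated as a 2.9-fold lower number from compound 2 to compound 3 (0.46 log units; beyond the scatter). Compound 3 is accordingly expected near 1500 nM, within 400 nM to 5000 nM.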

Compound 3, half-maximal effective concentration: 159 nM
Beside the measured number, compound 3's estimate is 9.4-fold (0.97 log units) above it; measured number below the stated range.
By their numbers in this assay, from the lowest: compounds 3 and 1 (each within the scatter of the next); then compound 2.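

At this place on the ring, meta to a large group, fluoro in place of methyl gives a 27-fold lower number from compound 2 to compound 3 (1.43 log units; beyond the scatter) in this assay, so exchanging one heavy atom for another can move the number by a large amount. The 3-fluorophenyl and 2-chlorophenyl compounds stand level, with a 1.8-fold lower number from compound 1 to compound 3 (0.26 log units; within the scatter), so the high number of compound 2 goes with the methyl rather than with any group at this place. Nothing measured here explains the size of this step. On these data alone, whether a chloro, hydroxyl or methoxy group at this same place would behave like fluoro or like methyl remains open.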